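The compounds below may be only part of what the source reports. "The series", "measured", "known", "first", "only" and "open" are said of these compounds alone.

Compound 1 `CCOC(=O)C12C(=O)OCC=C1COC2c1ccc(Cl)cc1`; compound 2 `CCOC(=O)C12C(=O)OCC=C1COC2c1ccc(Cl)c(Cl)c1`; compound 3 `CCOC(=O)C12C(=O)OCC=C1COC2c1cc(OC)c(OC)c(OC)c1`.

In a functional assay on QGY cells (Homo sapiens) for cytotoxicity, read by MTT assay (on this read-out higher numbers stand for weaker inhibition and lower numbers for stronger inhibition), compound 1 gives only a limit, > 1000000 nM. Compound 2 likewise gives a limit, > 1000000 nM. Compound 3 too gives a limit, > 1000000 nM. Compound 1 thus stands at no readable point: its own value is a limit, and the two further values are limits as well, so that all three sit at the limit of > 1000000 nM in this assay, at which 3 of the 3 values shown sit. Within the data shown here, the single measured step, a step that the two limits leave unreadable from compound 1 to compound 2, cannot be read from two limits. Compound 4 `CCOC(=O)C12C(=O)OCC=C1COC2c1ccc(N(C)C)cc1` differs from compound 1 by dimethylamino in place of chloro on an aromatic carbon. No readable step bears on this change, and the expected step that the limit leaves unreadable from compound 1 to compound 4 is one the numbers cannot place beyond the scatter. Compound 4 is therefore expected to give about 2000000 nM, within a range from 200000 nM to 20000000 nM.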

Compound 4, half-maximal inhibitory concentration: > 1000000 nM
Compound 4 gave a limit, no number; the forecaster's own chance of this, stated with the estimate: 85%; the middle value lies beyond the limit too.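

Among these compounds, compound 1 and compound 4 both stand as limits, and no step between them can be read. The compounds shown leave open whether any change on the shared core gives a readable value in this assay at all.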